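A few compounds are considered here, and "the series" means these few. Any claim that something is new, unique, unknown or untested is made for them only; others in the source may bear on it.

In a functional assay on K562 cells (Homo sapiens) for antiproliferative activity, read by MTT assay, with a stated time of 72 h (a higher number here means a weaker inhibitor, a lower number a stronger inhibitor), compound 1 `COc1cc(C(=O)c2sc3ccccc3c2-c2ccc(F)cc2)cc(OC)c1OC` gives 2100 nM, compound 2 `COc1cc(C(=O)c2sc3ccccc3c2-c2ccc(C)cc2)cc(OC)c1OC` gives 3500 nM and compound 3 `COc1cc(C(=O)c2sc3ccccc3c2Nc2ccccc2)cc(OC)c1OC` gives 2300 nM. Compound 3 therefore stands within the scatter of both others, as a 1.1-fold higher number from compound 1 to compound 3 (0.04 log units; within the scatter) and a 1.5-fold lower number from compound 2 to compound 3 (0.18 log units; within the scatter) show. Compound 4 `COc1ccc(Nc2c(C(=O)c3cc(OC)c(OC)c(OC)c3)sc3ccccc23)cc1` carries methoxy in place of hydrogen on an aromatic carbon, para to a large group: methoxy in place of hydrogen on an aromatic carbon. Among the compounds with values here, no measured step makes this exact change. The closest is methyl in place of fluoro on an aromatic carbon, a 1.7-fold higher number from compound 1 to compound 2 (0.22 log units; within the scatter), also within the scatter. No step beyond the scatter is therefore expected in this assay, and the expected step is a 1.5-fold lower number from compound 3 to compound 4 (0.19 log units; within the scatter). Compound 4 is estimated at 1500 nM, with an expected range from 250 nM to 5000 nM.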

Compound 4, half-maximal inhibitory concentration: 2900 nM
Compound 4: the middle estimate sits 1.9-fold (0.29 log units) below what was measured; measured number inside the range.
By their numbers in this assay, from the lowest: compounds 1, 3, 4 and 2 (each within the scatter of the next).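

Within the data shown here, measured directly at this place for the first time, methoxy in place of hydrogen on the anilino group gives, in this assay, a 1.3-fold higher number from compound 3 to compound 4 (0.10 log units; within the scatter). The (4-methoxyphenyl)amino group also cannot be told apart from the groups it replaces, with a 1.2-fold lower number from compound 2 to compound 4 (0.08 log units; within the scatter) and a 1.4-fold higher number from compound 1 to compound 4 (0.14 log units; within the scatter). No evidence is available to explain these results. The compounds shown leave open whether any group at this place can move the number beyond the scatter. An amine or a carboxylic acid in place of methoxy would test this.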